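The compounds below may be only part of what the source reports. "The series", "measured", "known", "first", "only" and "open" are said of these compounds alone.

Compound 1 `COc1cc2c(cc1N1C[C@@H](C)N[C@@H](C)C1)N(S(=O)(=O)Cc1cccc(I)c1)CC2` and compound 2 `COc1cc2c(cc1N1C[C@@H](C)N[C@@H](C)C1)N(S(=O)(=O)c1ccc(-c3ccccn3)cc1)CC2` share one core and differ only in the group carried on the sulfonyl sulfur. In a functional assay with growth hormone secretagogue receptor type 1 (Homo sapiens) as the target (a lower number here means a smaller maximal response, a higher number a larger maximal response), compound 1 gives 0.8, the lower of the two numbers, while compound 2 gives 1.1, a gap that goes beyond the usual scatter. Compound 3 `COc1cc2c(cc1N1C[C@@H](C)N[C@@H](C)C1)N(S(=O)(=O)c1ccc(-c3ccon3)s1)CC2` is the next step from compound 1: 5-(1,2-oxazol-3-yl)thiophen-2-yl in place of 3-iodobenzyl on a sulfonyl sulfur. Going by the values given here, no measured pair shows this change, so its size is a matter of expectation. An upward step is expected, a number 0.20 higher from compound 1 to compound 3 (beyond the scatter). Compound 3 is therefore expected to reach 1, between 0.8 and 1.2, because compound 2 gives 1.1.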

Compound 3, intrinsic activity: the largest response reached, as a fraction of the reference agonist's: 0.9
Compound 3: the middle estimate sits 0.10 above what was measured; the range from low to high includes it.
By their numbers in this assay, from the lowest: compounds 1 and 3 (each within the scatter of the next); then compound 2.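

In this assay, going by these compounds alone, replacing 3-iodobenzyl with 5-(1,2-oxazol-3-yl)thiophen-2-yl on the sulfonyl sulfur gives the first measured step at this position, a number 0.10 higher from compound 1 to compound 3 (within the scatter). The maximal response therefore stays within the scatter across this exchange of a benzyl group for a linked pair of five-membered aromatic rings. Nothing measured here accounts for this result. The compounds shown leave open how a small methyl group on the sulfonyl sulfur would behave. They also leave open whether a group bearing an amine or a carboxylic acid would keep this response.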